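Changing the Ketone Aryl Group in a Piperazine Series

This account rests on a few compounds, and the source may have more. Where it says the series, first, only, none or still open, it means among the compounds named here.

Compound 2 `O=C(CCN1CCN(c2ccc([N+](=O)[O-])cc2)CC1)c1ccc(Br)cc1` is one of two compounds tested in an ADME assay on Vero cells (Chlorocebus sabaeus) for cytotoxicity, read by resazurin assay, with a stated time of 72 h; a lower number here means a stronger inhibitor, a higher number a weaker inhibitor; the other is compound 1 `O=C(CCN1CCN(c2ccc(C(F)(F)F)cc2)CC1)c1ccc(Br)cc1`. In this assay compound 1 gives 78800 nM, and compound 2 gives 79800 nM. The step of a 1.0-fold higher number from compound 1 to compound 2 (0.01 log units; within the scatter) is within the scatter, so the two numbers cannot be told apart, and compound 2 stands level with compound 1 rather than apart from it. Compound 3 `O=C(CCN1CCN(c2ccc([N+](=O)[O-])cc2)CC1)c1ccc(F)c(Cl)c1` has not yet been measured; it differs from compound 2 by 3-chloro-4-fluorophenyl in place of 4-bromophenyl on a carbonyl carbon. Among the measured compounds shown here, the single measured step altered the other aromatic ring, so no measured step touches the group on the carbonyl carbon, and there is nothing here to point to a shift in either direction. The expected step of a 1.0-fold higher number from compound 2 to compound 3 (0.00 log units; within the scatter) is therefore one of no change beyond the scatter. The estimate for compound 3 in this assay is 80000 nM, within a range from 35000 nM to 180000 nM.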

Compound 3, half-maximal inhibitory concentration: 116000 nM
For compound 3 the middle estimate is 1.5-fold (0.16 log units) below the measured one; measured number inside the range.
By their numbers in this assay, from the lowest: compounds 1, 2 and 3 (each within the scatter of the next).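

Among the compounds shown here, this is the only measured step at the carbonyl carbon, and in this assay it reads a 1.5-fold higher number from compound 2 to compound 3 (0.16 log units; within the scatter), so the number shows no real difference. Replacing 4-bromophenyl with 3-chloro-4-fluorophenyl at this position therefore leaves the cytotoxicity reading unresolved from that of compound 2, just as the earlier step on the other aromatic ring did, and this group can be altered in this way without a measurable effect in this one pair. Nothing available here helps to explain this result.

From the compounds shown here alone, it remains open whether a plain phenyl group, or an aryl group carrying an amine or a carboxylic acid, on the carbonyl carbon would move the number beyond the scatter. The compounds shown also say nothing about a longer chain in place of the saturated chain carbon.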